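Amide substituent step from compound 2 to compound 3

A few compounds are considered here, and "the series" means these few. Any claim that something is new, unique, unknown or untested is made for them only; others in the source may bear on it.

Values from a functional assay on A549 cells (Homo sapiens) for inhibition, read by sulforhodamine B assay, with a stated time of 72 h; on this read-out higher numbers stand for weaker inhibition and lower numbers for stronger inhibition
- compound 1 `Nc1sc(-c2ccc(Cl)cc2)c(-c2ccc(Cl)cc2)c1C(=O)N1CCCCC1` gives 4620 nM
- compound 2 `CC(C)CNC(=O)c1c(N)sc(-c2ccc(Cl)cc2)c1-c1ccc(Cl)cc1` gives 21000 nM

Compound 2 has the higher number of the two measured compounds, and the nearest value is that of compound 1. Compound 3 `Nc1sc(-c2ccc(Cl)cc2)c(-c2ccc(Cl)cc2)c1C(=O)NC1CCCC1` keeps the shared core and carries cyclopentyl in place of isobutyl on an amide-type nitrogen. For the measured compounds named here, only one measured step bears on this change: a 4.5-fold higher number from compound 1 to compound 2 (0.66 log units; beyond the scatter), with isobutylamino in place of piperidin-1-yl on a carbonyl carbon. Compound 1 also holds a ring at the amide (4620 nM), so a modest move towards a lower number is expected in this assay, probably smaller than that single step. One pair gives only weak support. The expected size is a 2.3-fold lower number from compound 2 to compound 3 (0.37 log units; beyond the scatter) in this estimate. For compound 3 the estimated value is 9000 nM (range 3000 nM to 25000 nM).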

Compound 3, half-maximal inhibitory concentration: 6790 nM
Estimate against measurement, compound 3: 1.3-fold (0.12 log units) above; low and high end bracket the measured number.
By their numbers in this assay, from the lowest: compounds 1 and 3 (each within the scatter of the next); then compound 2.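

In this assay, replacing isobutyl with cyclopentyl on the amide-type nitrogen gives a 3.1-fold lower number from compound 2 to compound 3 (0.49 log units; beyond the scatter) while the amide hydrogen stays in place, so the carbon group alone can move the value at this position. Swapping piperidin-1-yl for cyclopentylamino gives a 1.5-fold higher number from compound 1 to compound 3 (0.17 log units; within the scatter) and therefore does not separate the two ring-bearing amides, despite the amide hydrogen present only in compound 3. Among these three compounds, both ring-bearing amides lie apart from the isobutyl amide, with no compound going against this, but no measurement here explains the difference.

Still open, on these data alone, is whether the trend holds for a straight butyl chain or a longer chain, or for a cyclohexyl ring. A morpholine ring or a carboxylic acid on the amide substituent also remains untested by the compounds shown here.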